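Working notes: lipophilicity of compounds 1 to 3

A few compounds are considered here, and "the series" means these few. Any claim that something is new, unique, unknown or untested is made for them only; others in the source may bear on it.

Compound 1 `COc1ccc(/C=N/NC(=O)COc2cccc3ccccc23)cc1O` gives 3.48 in a physicochemical assay for lipophilicity, measured as octanol-water partition; a higher number here means a more lipophilic compound, a lower number a more polar compound.
Compound 2 `C/C(=N\NC(=O)COc1cccc2ccccc12)c1ccccc1O` gives 3.08 in this assay.

In this assay compound 1 stands highest of the two numbers; compound 2 lies lower, and that gap is beyond the scatter. Compound 3 `COc1ccc(/C=N/NC(=O)COc2cccc3ccccc23)cc1` is not yet measured in this assay. Against compound 1 it differs as hydrogen in place of hydroxy on an aromatic carbon. Going by the values given here, no step between measured compounds bears on this change, so the expectation rests on the value of compound 1 alone. The step is expected to be upward and beyond the scatter, a number 0.42 log units higher from compound 1 to compound 3 (beyond the scatter). Compound 3 is estimated at 3.9, within 3.5 to 4.3.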

Compound 3, partition coefficient: 3.77
Beside the measured number, compound 3's estimate is 0.13 log units above it; measured number inside the range.
By their numbers in this assay, from the lowest: compound 2; then compounds 1 and 3 (each within the scatter of the next).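

In this assay, going by these compounds alone, hydrogen in place of hydroxy on this aromatic carbon, ortho to a methoxy group, gives a number 0.29 log units higher from compound 1 to compound 3 (within the scatter), so the loss of the hydroxy leaves no step that can be told from scatter at this position. Within the data shown here, this is the first single-place step, since compound 1 and compound 2 differ in more than one place. No measurement at hand explains the size of this step.

As far as these compounds go, whether an amine, a carboxylic acid or a longer alkoxy chain at this carbon would move the number beyond the scatter stays open. Also open, from the compounds shown here alone, is whether the same change would give a similar step on the ring of compound 2.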